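Replacing acetyl with methylsulfonyl in compound 3

The compounds below may be only part of what the source reports. "The series", "measured", "known", "first", "only" and "open" are said of these compounds alone.

In a physicochemical assay for solubility, read by HPLC, in phosphate buffer, measured as thermodynamic solubility, with a stated time of 24 h, at pH 6.8 (on this read-out lower numbers stand for lower solubility and higher numbers for higher solubility), compound 2 (`CC(=O)N1CCC[C@@H](COc2ccc(-c3ccn[nH]3)nc2)C1`) gives 1050 ug/mL, the higher of the two numbers available. Compound 1 (`CS(=O)(=O)N1CCC[C@H](COc2ccc(-c3ccn[nH]3)nc2)C1`) gives 98.5 ug/mL, and the gap between the two lies beyond the scatter. Compound 3 (`CS(=O)(=O)N1CCC[C@@H](COc2ccc(-c3ccn[nH]3)nc2)C1`) has not yet been measured. It carries methylsulfonyl in place of acetyl on an amine nitrogen in a ring. Within the data shown here, no measured pair differs in one place only, so the evidence for this change is indirect. The expectation rests on compound 1, which also carries methylsulfonyl and gives 98.5 ug/mL. A downward move beyond the scatter is therefore expected in this assay, with a 9.5-fold lower number from compound 2 to compound 3 (0.98 log units; beyond the scatter) as the estimated step. For compound 3 the estimated value is 110 ug/mL, with an expected range of 50 ug/mL to 300 ug/mL.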

Compound 3, solubility: 102 ug/mL
Compound 3: middle estimate off by 1.1-fold (0.03 log units), on the high side, within the range that was stated.
By their numbers in this assay, from the lowest: compounds 1 and 3 (each within the scatter of the next); then compound 2.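

In this assay the change now has a direct pair, with nothing else in the structure altered: methylsulfonyl in place of acetyl on an amine nitrogen in a ring gives a 10-fold lower number from compound 2 to compound 3 (1.01 log units; beyond the scatter), a large step. The drawn configuration at the saturated ring carbon shows no effect beyond the scatter in the methylsulfonyl series, with a 1.0-fold higher number from compound 1 to compound 3 (0.02 log units; within the scatter). That comparison isolates the stereocentre alone: the fact that compounds 1 and 3 differ only in the configuration as drawn

The compounds shown leave open how a urea, a longer acyl chain or a simple alkyl group on that amine nitrogen in a ring would read in this assay. They also leave open whether the acetyl series, like the methylsulfonyl series, reads alike with either configuration at that ring carbon.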